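From Ethylsulfonyl to Isopropylsulfonyl on a Shared Core

The compounds below may be only part of what the source reports. "The series", "measured", "known", "first", "only" and "open" are said of these compounds alone.

Compound 1 `CCc1noc(C2CCN(c3ncnc(Nc4ccc(S(C)(=O)=O)cc4)c3[N+](=O)[O-])CC2)n1` and compound 2 `CCS(=O)(=O)c1ccc(Nc2ncnc(N3CCC(c4nc(C(C)C)no4)CC3)c2[N+](=O)[O-])cc1` share one core and differ in more than one place. In a functional assay for agonist activity at Glucose-dependent insulinotropic receptor (Homo sapiens) (a higher number here means that more compound is needed for the effect, a lower number that less compound is needed), compound 1 gives 10 nM, and compound 2 gives 17 nM, the higher of the two numbers, though the gap to compound 1 lies within the scatter. Compound 3 `CC(C)c1noc(C2CCN(c3ncnc(Nc4ccc(S(=O)(=O)C(C)C)cc4)c3[N+](=O)[O-])CC2)n1` carries the change (methyl in place of hydrogen on a saturated chain carbon bound to a saturated chain carbon and a sulfonyl sulfur), which one bond further out reads ethylsulfonyl to isopropylsulfonyl. For the measured compounds named here, no measured pair shows this change, so in this assay a step no larger than the scatter is expected, in either direction. For compound 3 a value of 20 nM is expected, between 8 nM and 50 nM. This expectation means a step of a 1.2-fold higher number from compound 2 to compound 3 (0.07 log units; within the scatter).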

Compound 3, half-maximal effective concentration: 7.8 nM
The estimate for compound 3 lay 2.6-fold (0.41 log units) above the measured number; the whole stated range lies above it.
By their numbers in this assay, from the lowest: compounds 3, 1 and 2 (each within the scatter of the next, the first and the last beyond it).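

Replacing ethylsulfonyl with isopropylsulfonyl, with the rest of the molecule unchanged, gives in this assay a 2.2-fold lower number from compound 2 to compound 3 (0.34 log units; beyond the scatter), a modest step that lies beyond the scatter. So a methyl on this saturated chain carbon bound to the sulfonyl sulfur is tolerated here, and the number falls rather than rises. No accompanying measurement says why this step occurs. From the compounds shown here alone, whether a tert-butyl or cyclopropyl group, or an amine on the sulfonyl sulfur, would lower the number further stays open. So does whether the same step appears with a different group elsewhere on the shared core.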